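Moving the methoxy group: compound 3 to compound 4

This account rests on a few compounds, and the source may have more. Where it says the series, first, only, none or still open, it means among the compounds named here.

Measured so far:
compound 1 `CC(=O)n1cc(/C=C(/C(=O)O)c2ccccc2)c2cc(OCc3ccccc3)ccc21` — 55500 nM
compound 2 `COc1ccc(Cn2cc(/C=C(/C(=O)O)c3ccccc3)c3cc(OCc4ccccc4)ccc32)cc1` — 97000 nM
compound 3 `COc1ccccc1/C(=C\c1cn(C(C)=O)c2ccc(OCc3ccccc3)cc12)C(=O)O` — > 100000 nM

In a functional assay on KB cells (Homo sapiens) for cytotoxicity, read by MTT assay, with a stated time of 72 h (a higher number here means a weaker inhibitor, a lower number a stronger inhibitor), compound 1 gives 55500 nM and compound 2 gives 97000 nM. For compound 3 the value > 100000 nM is a limit of the assay, not a number; compound 3 stands only at that limit. The step of an at least 1.8-fold higher number from compound 1 to compound 3 (0.25 log units; that floor lies within the scatter) is therefore known only as a floor, and the limit of > 100000 nM in this assay, at which 1 of the 3 values shown sits, is the relevant boundary. The step of a 1.7-fold higher number from compound 1 to compound 2 (0.24 log units; within the scatter) concerns the aromatic nitrogen and does not bear on the aryl ring.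

Compound 4 `COc1ccc(/C(=C\c2cn(C(C)=O)c3ccc(OCc4ccccc4)cc23)C(=O)O)cc1` differs from compound 3 by 4-methoxyphenyl in place of 2-methoxyphenyl on a double-bonded chain carbon bound to a carbonyl carbon and a double-bonded chain carbon. For the measured compounds named here, no measured step moves the methoxy on this ring, so no step beyond the scatter is expected in this assay. Compound 4 is estimated at 80000 nM, with a range from 30000 nM to 200000 nM. The expected step is an at least 1.2-fold lower number from compound 3 to compound 4 (0.09 log units; that floor lies within the scatter).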

Compound 4, half-maximal inhibitory concentration: > 100000 nM
Compound 4: only a limit was reported; the forecaster's own chance of this, stated with the estimate: 40%; at least 1.2-fold (0.09 log units) between middle value and limit.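

In this assay compound 4 gives > 100000 nM, a limit of the assay and not a number. For the compounds shown here, the one readable step is an at least 1.8-fold higher number from compound 1 to compound 4 (0.25 log units; that floor lies within the scatter), so 4-methoxyphenyl, like 2-methoxyphenyl in compound 3, shows no step beyond the scatter. The step between compound 3 and compound 4 cannot be read, because both stand at the limit: the limit of > 100000 nM in this assay, at which 2 of the 4 values shown sit.

Still open, on these data alone, is where compound 3 and compound 4 truly lie beyond that limit. Also open, as far as these compounds go, is whether an amine or a hydroxyl group on this aryl ring would give a readable number.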